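Swapping fluoro for methyl on the aromatic ring

The source may report more compounds than this note shows. Statements on the series, on what has been measured and on what is new or still open speak of the compounds shown alone.

Compound 2 `COc1ccc(F)c(N2CCC(COc3cccc(C(CC(=O)O)C4CC4)c3)CC2)c1` gives 114% in a functional assay on cells for agonist activity at Free fatty acid receptor 1 (Homo sapiens), read by FLIPR and calcium flux, with a stated time of 60 min; on this read-out higher numbers stand for larger maximal responses and lower numbers for smaller maximal responses. Within the data shown here, the only other measured compound, compound 1 `COc1ccc(CCCC(C)(C)C)c(N2CCC(COc3cccc(C(CC(=O)O)C4CC4)c3)CC2)c1`, gives 106% in this assay. The two values lie within the scatter of each other: a number 8 percentage points higher from compound 1 to compound 2 (within the scatter). Compound 3 `COc1ccc(C)c(N2CCC(COc3cccc(C(CC(=O)O)C4CC4)c3)CC2)c1` differs from compound 2 by methyl in place of fluoro on an aromatic carbon. Among the measured compounds shown here, the one measured step at this position, fluoro in place of 4,4-dimethylpentyl on an aromatic carbon, changed nothing beyond the scatter, and nothing measured here points to a different outcome for methyl. The step expected here is a number 6 percentage points lower from compound 2 to compound 3 (within the scatter), none beyond the scatter. Compound 3 is therefore estimated at 108%, between 95% and 120%.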

Compound 3, largest response reached (Emax), in percent of the reference or control that the assay uses: 113%
For compound 3 the middle estimate is 5 percentage points below the measured one; measured number inside the range.
By their numbers in this assay, from the lowest: compounds 1, 3 and 2 (each within the scatter of the next).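

In this assay, the result is a number 1 percentage points lower from compound 2 to compound 3 (within the scatter), so fluoro and methyl at this place on the ring cannot be told apart. Methyl also reads level with the much longer 4,4-dimethylpentyl chain, with a number 7 percentage points higher from compound 1 to compound 3 (within the scatter), so all three groups now give maximal responses within the scatter of each other. Nothing given here offers an explanation for this. Still open, going by these compounds, is whether an amine or a carboxylic acid at this place would move the response beyond the scatter.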